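Bromo in place of hydrogen on the benzylidene ring

The compounds below may be only part of what the source reports. "The series", "measured", "known", "first", "only" and "open" are said of these compounds alone.

Compound 1 `Cn1nnnc1SCC(=O)N/N=C/c1ccccc1` serves as the reference point of this small set. In an ADME assay on NIH3T3 cells (Mus musculus) for cytotoxicity, read by XTT assay, with a stated time of 24 h (on this read-out higher numbers stand for weaker inhibition and lower numbers for stronger inhibition), compound 1 gives 9700000 nM, the highest of the two numbers shown; the nearest number is that of compound 3, reached by a 1.5-fold lower number from compound 1 to compound 3 (0.19 log units; within the scatter). Compound 3 `Cn1nnnc1SCC(=O)N/N=C/c1cccc(F)c1` gives 6320000 nM in this assay. Compound 2 `COc1ccc(/C=N/NC(=O)CSc2nnnn2C)cc1` returns > 10000000 nM in this assay, which is a limit of the assay and not a number, as noted in the limit of > 10000000 nM in this assay, at which 1 of the 3 values shown sits.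

Compound 4 `Cn1nnnc1SCC(=O)N/N=C/c1ccccc1Br` has not been measured. It differs from compound 1 by bromo in place of hydrogen on an aromatic carbon. Two measured steps from compound 1 bear on it: an at least 1.0-fold higher number from compound 1 to compound 2 (0.01 log units; that floor lies within the scatter) and a 1.5-fold lower number from compound 1 to compound 3 (0.19 log units; within the scatter). Both are substitutions of hydrogen on an aromatic carbon of the same ring, and the step to compound 3 likewise brings in a halogen; both stay within the scatter. Within the data shown here, no measured compound carries bromo, and none carries a group at the place named for compound 4, so the expectation rests on these two steps alone. Compound 4 is therefore expected to show no step beyond the scatter, a 1.2-fold lower number from compound 1 to compound 4 (0.08 log units; within the scatter). For compound 4 a value of 8000000 nM is estimated, within a range from 3000000 nM to 20000000 nM, with a real chance that only a limit is returned.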

Compound 4, half-maximal inhibitory concentration: 20000 nM
Beside the measured number, compound 4's estimate is 400-fold (2.60 log units) above it, and the stated range ends above it.
By their numbers in this assay, from the lowest: compound 4; then compounds 3 and 1 (each within the scatter of the next). At a limit, above all of these: compound 2.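

In this assay, among these compounds, bromo in place of hydrogen on an aromatic carbon, at a place ortho to a large group, gives a 490-fold lower number from compound 1 to compound 4 (2.69 log units; beyond the scatter), the first step that lies beyond the scatter. The earlier substitutions of hydrogen on the same ring, methoxy in compound 2 and fluoro in compound 3, sit at other places and show no step beyond the scatter from compound 1, so substitution on this ring does not by itself bring such a drop, and this place, this group or the two together must matter. Compound 2 stands at a limit of the assay and not at a number, so its step is only a floor: the limit of > 10000000 nM in this assay, at which 1 of the 4 values shown sits.

Group and place change together in compound 4, so the compounds shown cannot separate the two; fluoro or methoxy at this place, or bromo at another place on the ring, would tell them apart. Going by these compounds, whether chloro, an amine, a carboxylic acid or a longer chain at this place would give a step of similar size also stays open.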